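Trimethoxyphenyl in place of methoxyphenyl: cytotoxicity notes

The source may hold more compounds than are shown below. What is called first, only, known or untested is meant among the compounds shown, and "the series" means these compounds.

Compound 1 `COc1ccc(C2=NN(C(=O)c3cccnc3)C(c3cn(C)c4ccc(Br)cc34)C2)cc1` is the reference. In an ADME assay on HEK-293T cells (Homo sapiens) for cytotoxicity, read by MTT assay, with a stated time of 48 h (a higher number here means that more compound is tolerated, a lower number that less compound is tolerated), compound 1 gives > 300000 nM, which is a limit of the assay. Compound 2 `COc1cc(C2=NN(C(=O)c3cccnc3)C(c3cn(C)c4ccc(Br)cc34)C2)cc(OC)c1OC` gives 131000 nM in this assay. The change 3,4,5-trimethoxyphenyl in place of 4-methoxyphenyl on a carbon with a double bond to nitrogen brings an at least 2.2-fold lower number from compound 1 to compound 2 (0.35 log units; beyond the scatter); the size is known only as a bound because the limit of > 300000 nM in this assay, at which 2 of the 3 values shown sit, is where compound 1 sits. Compound 3 `COc1ccc(C2=NN(C(=O)c3ccc(OC)nc3)C(c3cn(C)c4ccc(OC)cc34)C2)cc1` gives > 300000 nM in this assay, again a limit of the assay. The difference between the cores of compound 1 and compound 3 is not broken down here. Compound 4 `COc1ccc2c(c1)c(C1CC(c3cc(OC)c(OC)c(OC)c3)=NN1C(=O)c1ccc(OC)nc1)cn2C` carries the same kind of change, (3,4,5-trimethoxyphenyl in place of 4-methoxyphenyl on a carbon with a double bond to nitrogen); around the place, the ring atom bears a (6-methoxypyridin-3-yl)carbonyl group rather than a (pyridin-3-yl)carbonyl group. The expected step is an at least 2.3-fold lower number from compound 3 to compound 4 (0.36 log units; beyond the scatter), resting on an at least 2.2-fold lower number from compound 1 to compound 2 (0.35 log units; beyond the scatter). Compound 4 is estimated at 130000 nM in this assay, between 60000 nM and 300000 nM.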

Compound 4, half-maximal cytotoxic concentration: > 300000 nM
Compound 4 gave a limit, no number (the forecaster's own chance of this, stated with the estimate: 35%); at least 2.3-fold (0.36 log units) between middle value and limit.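

Compound 3 and compound 4 both give only a limit of the assay, so no step between them can be read: the limit of > 300000 nM in this assay, at which 3 of the 4 values shown sit.

As far as these compounds go, whether 3,4,5-trimethoxyphenyl in place of 4-methoxyphenyl changes the tolerated concentration on the core of compound 3 remains open.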